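This account rests on a few compounds, and the source may have more. Where it says the series, first, only, none or still open, it means among the compounds named here.

Working notes on the series. The cytotoxicity read-out is an ADME assay on L1210/0 cells (Mus musculus) for cytotoxicity, with a stated time of 48 h; on this read-out lower numbers stand for stronger inhibition and higher numbers for weaker inhibition. Compound 1, `OC[C@H]1C[C@@H](Cn2cnc3c(-c4ccccc4)ncnc32)c2ccccc21`, gives 28100 nM in this assay. Compound 2, `Cc1ccc(-c2ncnc3c2ncn3C[C@@H]2C[C@H](CO)c3ccccc32)cc1`, gives 15400 nM in this assay. Compound 3, `Cc1cn(C[C@@H]2C[C@H](CO)c3ccccc32)c(=O)[nH]c1=O`, carries a different core; in this assay compound 3 gives only a limit, > 200000 nM, which is the limit of > 200000 nM in this assay, at which 1 of the 3 values shown sits. How the core of compound 3 differs from the core of compound 2 is not broken down here.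

Compound 4, `O=c1ccn(C[C@@H]2C[C@H](CO)c3ccccc32)c(=O)[nH]1`, has not yet been measured in this assay. Between compound 3 and compound 4 the difference is hydrogen in place of methyl on an aromatic carbon. The same kind of change, measured once, is hydrogen in place of methyl on an aromatic carbon, and its effect was a 1.8-fold higher number from compound 2 to compound 1 (0.26 log units; within the scatter). What surrounds the place differs: for the measured pair the aromatic carbon sits on a six-membered aromatic ring of carbon only, para to a large group; for the unmeasured pair it sits on a six-membered aromatic ring with 2 nitrogen, ortho to a group of 1 heavy atom, two atoms from the ring nitrogen, meta to a large group, para to a group of 1 heavy atom.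

The expectation for compound 4 rests on the measured step, which was within the scatter, and on compound 3 sitting at the limit > 200000 nM. The expected step is a step that the limit leaves unreadable from compound 3 to compound 4, and compound 4 is estimated at 250000 nM, between 100000 nM and 600000 nM, most likely reported again as a limit.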

Compound 4, half-maximal inhibitory concentration: > 200000 nM
Compound 4 was reported as a limit; the forecaster's own chance of this, stated with the estimate: 80%; the middle value lies beyond the limit too.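

No new step can be read from compound 3 to compound 4 in this assay, as both results are limits and not numbers: the limit of > 200000 nM in this assay, at which 2 of the 4 values shown sit.

The compounds shown leave open whether hydrogen in place of methyl on an aromatic carbon changes the cytotoxicity read-out at all on the core shared by compound 3 and compound 4.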